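The source may report more compounds than this note shows. Statements on the series, on what has been measured and on what is new or still open speak of the compounds shown alone.

Going by the values given here, compound 2 `COc1ccc(CNc2ccc(-c3c(N)nc(N)nc3COCc3ccccc3)cc2)cc1` gives 7.7 nM in an in vitro assay on CHOK cells for displacement of a labelled ligand from growth hormone secretagogue receptor type 1 (Homo sapiens) (a lower number here means a stronger inhibitor, a higher number a weaker inhibitor), the higher of the two numbers measured so far; its nearest neighbour, compound 1 `N#Cc1ccc(CNc2ccc(-c3c(N)nc(N)nc3COCc3ccccc3)cc2)cc1`, gives 2.8 nM in this assay. Among the compounds with values here, the single measured step, a 2.8-fold higher number from compound 1 to compound 2 (0.44 log units; beyond the scatter), arose from methoxy in place of cyano on an aromatic carbon. Compound 3 `Nc1nc(N)c(-c2ccc(CNc3ccc([N+](=O)[O-])cc3)cc2)c(COCc2ccccc2)n1` has not yet been measured; it differs from compound 2 by ((4-nitrophenyl)amino)methyl in place of (4-methoxybenzyl)amino on an aromatic carbon. Within the data shown here, this change is wider than the measured one: besides a new group at the end of the side chain, the linking atoms are joined in a different order, and no measured pair shows that rearrangement. Among the measured compounds shown here, the modest size of a 2.8-fold higher number from compound 1 to compound 2 (0.44 log units; beyond the scatter) is the only guide, and it suggests that a change at this end of the molecule need not move the number far. Compound 3 is therefore expected to give about 5 nM, within 1.5 nM to 20 nM, which amounts to an expected step of a 1.5-fold lower number from compound 2 to compound 3 (0.19 log units; within the scatter) that may well stay inside the scatter.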

Compound 3, half-maximal inhibitory concentration: 0.8 nM
For compound 3 the middle estimate is 6.3-fold (0.80 log units) above the measured one, and the stated range ends above it.
By their numbers in this assay, from the lowest: compound 3; then compound 1; then compound 2.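

In this assay, replacing (4-methoxybenzyl)amino with ((4-nitrophenyl)amino)methyl gives a 9.6-fold lower number from compound 2 to compound 3 (0.98 log units; beyond the scatter), and the same replacement starting from the cyano analogue gives a 3.5-fold lower number from compound 1 to compound 3 (0.54 log units; beyond the scatter), so this place on the ring can move the number further than the earlier pair showed, and compound 3 stands lowest of the three. Both steps change the end group and the order of the linking atoms together, and no pair shown separates the two. There is no measured evidence here on why the number falls.

As far as these compounds go, it remains open whether the gain follows the nitro group or the rearranged linker, which a (4-nitrobenzyl)amino group and a ((4-methoxyphenyl)amino)methyl group would each address. From the compounds shown here alone, how a carboxylic acid or an amine at the end of this side chain would fare also remains open.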